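Triazole thioether piperazines: cytotoxicity outlook for compound 4

The source may report more compounds than this note shows. Statements on the series, on what has been measured and on what is new or still open speak of the compounds shown alone.

Measured compounds:
compound 1 `Cc1ccc(-c2nnc(SCCCN3CCN(c4cccc(Cl)c4)CC3)[nH]2)cc1` gives > 300000 nM
compound 2 `Cc1cccc(-c2nnc(SCCCN3CCN(c4ccccc4)CC3)[nH]2)c1` gives 248000 nM
compound 3 `Cc1cccc(-c2nnc(SCCCN3CCN(c4ccccn4)CC3)[nH]2)c1` gives > 300000 nM

In a functional assay on THP-1 cells (Homo sapiens) for cytotoxicity, read by MTT assay, with a stated time of 24 h (on this read-out higher numbers stand for weaker inhibition and lower numbers for stronger inhibition), compound 3 has only a limit of the assay, not a number. The same is true of compound 1, so two of the three values shown sit at the limit (the limit of > 300000 nM in this assay, at which 2 of the 3 values shown sit); only compound 2 gives a number within range. Within the data shown here, the one step between measured compounds that differ in one place is an at least 1.2-fold higher number from compound 2 to compound 3 (0.08 log units; that floor lies within the scatter), where pyridin-2-yl replaces phenyl on the amine nitrogen in the ring; its floor lies within the scatter.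

Compound 4 `Clc1ccccc1-c1nnc(SCCCN2CCN(c3ccccn3)CC2)[nH]1` is not yet measured. It differs from compound 3 by 2-chlorophenyl in place of 3-methylphenyl on an aromatic carbon of the five-membered ring with three nitrogen atoms. No measured step touches that aryl group, since the only step shown changes the group on the amine nitrogen. Compounds 1 and 3 differ in two places and both sit at the limit, which gives no direction for this change. Among the measured compounds shown here, with no bearing step, no step beyond the scatter is expected for compound 4 in this assay, so the estimate is a number no higher from compound 3 to compound 4 (the limit leaves the size open), most likely again reported as a limit. Compound 4 is therefore estimated at 300000 nM, with a range from 150000 nM to 700000 nM.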

Compound 4, half-maximal inhibitory concentration: > 300000 nM
Compound 4: no number, only a limit (the forecaster's own chance of this, stated with the estimate: 70%); the middle value sits exactly at the limit.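

In this assay compound 3 and compound 4 both carry only a limit, so no step can be read between them: the limit of > 300000 nM in this assay, at which 3 of the 4 values shown sit. The compounds shown leave open whether 2-chlorophenyl in place of 3-methylphenyl on an aromatic carbon shifts this read-out at all, and in which direction.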